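The source may hold more compounds than are shown below. What is called first, only, known or untested is meant among the compounds shown, and "the series" means these compounds.

Compound 1 `O=c1cc(-c2ccccc2)oc2cc(OCc3ccccc3)c(OCCCCN3CCCCC3)c(O)c12` gives 3000 nM; compound 2 `O=c1cc(-c2ccccc2)oc2cc(OCc3ccccc3)c(OCCCN3CCCCC3)c(O)c12` gives 4600 nM; compound 3 `O=c1cc(-c2ccccc2)oc2cc(O)c(OCCCCN3CCCCC3)c(O)c12` gives 52700 nM.

In a functional assay on BCG823 cells (Homo sapiens) for antiproliferative activity, read by MTT assay, with a stated time of 48 h (on this read-out higher numbers stand for weaker inhibition and lower numbers for stronger inhibition), compound 3 stands at the highest number of the three: compound 1 reaches compound 3 by an 18-fold higher number from compound 1 to compound 3 (1.24 log units; beyond the scatter), and compound 2 sits well below compound 3 as well. Compound 4 `CN1CCN(CCCCOc2c(O)cc3oc(-c4ccccc4)cc(=O)c3c2O)CC1` differs from compound 3 by 4-methylpiperazin-1-yl in place of piperidin-1-yl on a saturated chain carbon, four bonds along the chain from an oxygen on an aromatic ring. For the measured compounds named here, no measured step touches the amine ring itself; the nearest comparison, a 1.5-fold higher number from compound 1 to compound 2 (0.19 log units; within the scatter), alters only the chain carrying that ring and stays within the scatter, while an 18-fold higher number from compound 1 to compound 3 (1.24 log units; beyond the scatter) concerns the benzyl group and not this position. On that basis compound 4 is expected to change little in this assay, with a 1.1-fold lower number from compound 3 to compound 4 (0.02 log units; within the scatter) as the estimate. Compound 4 is therefore expected near 50000 nM, between 18000 nM and 140000 nM.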

Compound 4, half-maximal inhibitory concentration: 82900 nM
Compound 4: middle estimate off by 1.7-fold (0.22 log units), on the low side, within the range that was stated.
By their numbers in this assay, from the lowest: compounds 1 and 2 (each within the scatter of the next); then compounds 3 and 4 (each within the scatter of the next).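

In this assay, for the compounds shown here, 4-methylpiperazin-1-yl in place of piperidin-1-yl, on a saturated chain carbon four bonds along the chain from an oxygen on an aromatic ring, gives a 1.6-fold higher number from compound 3 to compound 4 (0.20 log units; within the scatter), the first measured step that touches the amine ring itself. Among these two compounds without the benzyl group, this exchange of rings therefore stays within the scatter. Nothing measured on these compounds accounts for this result. Going by these compounds, whether the same exchange holds with the benzyl group in place remains open. So does the outcome with a morpholine ring or a simple dimethylamino group at this position.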